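This account rests on a few compounds, and the source may have more. Where it says the series, first, only, none or still open, it means among the compounds named here.

Of the compounds shown here, three sharing one core have been tested in an ADME assay on WI-38 cells (Homo sapiens) for inhibition, read by MTT assay, with a stated time of 72 h; on this read-out lower numbers stand for stronger inhibition and higher numbers for weaker inhibition. Compound 1 `NC1(CCn2cc(F)c(=O)[nH]c2=O)OC(=O)C(OCc2ccccc2)=C1OCc1ccccc1` gives 36200 nM. Compound 2 `NC1(CCn2ccc(=O)[nH]c2=O)OC(=O)C(OCc2ccccc2)=C1OCc1ccccc1` gives a limit of the assay, > 100000 nM. Compound 3 `Nc1ccn(CCC2(N)OC(=O)C(OCc3ccccc3)=C2OCc2ccccc2)c(=O)n1` gives 88900 nM, the higher of the two numbers seen; its nearest neighbour is compound 1, with a 2.5-fold higher number from compound 1 to compound 3 (0.39 log units; beyond the scatter). Compound 4 `NC1(CCn2c(=O)[nH]c(=O)[nH]c2=O)OC(=O)C(OCc2ccccc2)=C1OCc1ccccc1` is not yet measured; it differs from compound 3 by a group of 9 heavy atoms (3 carbon, 3 nitrogen, 3 oxygen; one six-membered aromatic ring with 3 hetero atoms) in place of a group of 8 heavy atoms (4 carbon, 3 nitrogen, 1 oxygen; one six-membered aromatic ring with 2 hetero atoms), on a saturated chain carbon, two bonds along the chain from a saturated ring carbon. Earlier exchanges of the ring at this same place gave a 2.5-fold higher number from compound 1 to compound 3 (0.39 log units; beyond the scatter) and an at least 1.1-fold lower number from compound 2 to compound 3 (0.05 log units; that floor lies within the scatter), and an at least 2.7-fold higher number from compound 1 to compound 2 (0.44 log units; beyond the scatter) likewise stayed modest, so the numbers have moved little. A step of a 1.0-fold higher number from compound 3 to compound 4 (0.01 log units; within the scatter) is therefore expected, with no change beyond the scatter and a fair chance of another limit. Compound 4 is estimated at 90000 nM, within 35000 nM to 250000 nM.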

Compound 4, half-maximal inhibitory concentration: > 100000 nM
Compound 4 was reported as a limit; the forecaster's own chance of this, stated with the estimate: 45%; middle value at least 1.1-fold (0.04 log units) away from the limit.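

The reading for compound 4 is a limit of the assay, not a number: the limit of > 100000 nM in this assay, at which 2 of the 4 values shown sit. Going by these compounds alone, exchanging the ring at this place, on a saturated chain carbon, gives an at least 1.1-fold higher number from compound 3 to compound 4 (0.05 log units; that floor lies within the scatter), so no real change can be claimed, while an at least 2.7-fold higher number from compound 1 to compound 4 (0.44 log units; beyond the scatter) makes compound 1 the only compound with steps beyond the scatter to all the others; the step between compound 2 and compound 4 cannot be read. From the compounds shown here alone, whether a chloro or methyl group in place of the fluoro would give a similar number remains open, as does the effect of a longer chain.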